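Bombesin receptor subtype-3 agonists: biphenyl acid series, notes

The source may report more compounds than this note shows. Statements on the series, on what has been measured and on what is new or still open speak of the compounds shown alone.

Measured compounds:
compound 1 `CCCCc1cnc(C(CC)Cc2ccc(-c3ccccc3C(=O)O)cc2)[nH]1` 2720 nM
compound 2 `Cc1cccc(Cc2cnc(CCc3ccc(-c4ccccc4C(=O)O)cc3)[nH]2)c1` 4310 nM
compound 3 `CCCCc1cnc(C(CCC)Cc2ccc(-c3ccccc3C(=O)O)cc2)[nH]1` 1180 nM

All three share a biphenyl carboxylic acid linked through a saturated chain to an imidazole. In an in vitro functional assay on cells for agonist activity at Bombesin receptor subtype-3 (Homo sapiens), read by luminescence and calcium flux (on this read-out higher numbers stand for an effect only at larger amounts of compound and lower numbers for an effect already at smaller amounts), compound 2 gives the highest of the three numbers; its nearest neighbour is compound 1, a gap that lies within the scatter, so no order between compound 2 and compound 1 can be claimed. Compound 3 stands furthest from compound 2, and that gap lies beyond the scatter.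

Among the measured compounds shown here, the one step recorded between measured compounds is a 2.3-fold lower number from compound 1 to compound 3 (0.36 log units; beyond the scatter). It concerns the chain beside the imidazole, not the benzyl substituent, and so it does not bear on the change now in question.

Compound 4 `O=C(O)c1ccccc1-c1ccc(CCc2ncc(Cc3cccc(F)c3F)[nH]2)cc1` differs from compound 2 in one place: 2,3-difluorophenyl in place of 3-methylphenyl on a saturated chain carbon bound to an aromatic carbon. For the measured compounds named here, no measured pair reports an exchange of this kind on the aryl ring of the benzyl group, so there is no step to carry over. In the absence of a relevant precedent, compound 4 is expected to land close to compound 2, with a step of a 1.1-fold lower number from compound 2 to compound 4 (0.03 log units; within the scatter) that is not expected to exceed the scatter. Compound 4 is therefore estimated at 4000 nM, with a plausible range from 1300 nM to 12000 nM.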

Compound 4, half-maximal effective concentration: 87 nM
The estimate for compound 4 lay 46-fold (1.66 log units) above the measured number; measured number below the stated range.
By their numbers in this assay, from the lowest: compound 4; then compound 3; then compounds 1 and 2 (each within the scatter of the next).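

In this assay, among the compounds shown here, the aryl group on a saturated chain carbon bound to an aromatic carbon proves to be a strong determinant of the number: 2,3-difluorophenyl in place of 3-methylphenyl gives a 50-fold lower number from compound 2 to compound 4 (1.69 log units; beyond the scatter), a large step, whereas the only earlier step, made elsewhere in the molecule, was modest. For the compounds shown here, the earlier compounds include no pair that changes this group, so this is the first sign of how sensitive the series is here; the step occurs although the ring type, the absence of hydrogen-bond donors and acceptors, and the absence of net charge all stay the same. Nothing available accounts for the size of the step.

Because the methyl group leaves and two fluorines enter in one exchange, the pair cannot separate their contributions, and a plain phenyl, a monofluorophenyl or a chlorophenyl at this place would be needed to do so. Going by these compounds, it also remains open whether 2,3-difluorobenzyl would give a step of similar size on the branched chain of compound 3 rather than the chain of compound 2.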